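The compounds below may be only part of what the source reports. "The series", "measured", "known", "first", "only" and "open" are said of these compounds alone.

Compound 1 `CC(C)(C)c1ccc(/C=C/C(=O)c2ccc(OCC(=O)N[C@H]3CCOC3=O)cc2)cc1` — in a functional assay on PC-3 cells (Homo sapiens) for antiproliferative activity, read by MTT assay, with a stated time of 72 h (on this read-out lower numbers stand for stronger inhibition and higher numbers for weaker inhibition), compound 1 gives 10600 nM.
Compound 2 `Cc1cc(Cl)ccc1NCC(=O)N[C@H]1CCOC1=O` — compound 2 reaches only a limit of this assay, > 64000 nM.
Compound 3 `O=C1OCC[C@@H]1NC(=S)SCCOc1ccc(Cl)cc1` — compound 3 likewise reaches only a limit, > 64000 nM.

Among the compounds with values here, compound 1 thus holds the only measured number here; the two others sit at the limit of > 64000 nM in this assay, at which 2 of the 3 values shown sit. No step between two measured compounds is shown. Compound 4 `O=C(COc1ccc(C(=O)/C=C/c2ccc(F)c(F)c2)cc1)N[C@H]1CCOC1=O` differs from compound 1 in one place: 3,4-difluorophenyl in place of 4-(tert-butyl)phenyl on a double-bonded chain carbon bound to a double-bonded chain carbon. Within the data shown here, with no measured step to lean on, the account expects compound 4 to stay close to compound 1, at most a modest loss, estimated as a 1.5-fold higher number from compound 1 to compound 4 (0.18 log units; within the scatter). Compound 4 is therefore expected at about 16000 nM, within a range of 4000 nM to 55000 nM.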

Compound 4, half-maximal inhibitory concentration: 21900 nM
The estimate for compound 4 lay 1.4-fold (0.14 log units) below the measured number, and the stated range covers the measured number.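

Within the data shown here, the change from 4-(tert-butyl)phenyl to 3,4-difluorophenyl on a double-bonded chain carbon bound to a double-bonded chain carbon gives the first readable step in this assay: a 2.1-fold higher number from compound 1 to compound 4 (0.32 log units; beyond the scatter). The step is modest, and compound 4 still gives a measured number, so this position accepts a smaller, fluorinated phenyl with only a limited loss. Nothing shown here accounts for the size of this step. Still open, as far as these compounds go, is how a phenyl carrying an amine or a carboxylic acid would read at this position.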